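A few compounds are considered here, and "the series" means these few. Any claim that something is new, unique, unknown or untested is made for them only; others in the source may bear on it.

Of the compounds shown here, three of a shared core have been measured in a functional assay on SF-539 cells (Homo sapiens) for inhibition, read by sulforhodamine B assay, with a stated time of 48 h; on this read-out lower numbers stand for stronger inhibition of growth and higher numbers for weaker inhibition of growth. Compound 1 `Nc1cc(N)c2nc(-c3ccccc3)c(NCc3ccc(Cl)c(Cl)c3)nc2c1` gives 18600 nM, compound 2 `Nc1cc(N)c2nc(-c3ccccc3)c(Sc3ccc(F)cc3)nc2c1` gives 39800 nM, and compound 3 `COc1cc(CNc2nc3cc(N)cc(N)c3nc2-c2ccccc2)cc(OC)c1OC` gives 7940 nM. Compound 2 stands at the highest number of the three: compound 1 sits a step below it that lies beyond the scatter, and compound 3 further still.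

Compound 4 `Nc1cc(N)c2nc(-c3ccccc3)c(Sc3ccc(Cl)c(Cl)c3)nc2c1` has not yet been measured. It differs from compound 2 as follows (3,4-dichlorophenyl in place of 4-fluorophenyl on a sulfur).

Among the measured compounds shown here, with no matching step among the measured compounds, the direction is uncertain. Compound 1, which also carries two chlorine atoms, gives 18600 nM, so a modest move toward lower numbers is expected, with the step of a 1.8-fold lower number from compound 2 to compound 4 (0.26 log units; within the scatter) expected to stay small. Compound 4 is estimated at 22000 nM, within a range from 8000 nM to 55000 nM.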

Compound 4, concentration for total growth inhibition: 41700 nM
Compound 4: middle estimate off by 1.9-fold (0.28 log units), on the low side; the range from low to high includes it.
By their numbers in this assay, from the lowest: compound 3; then compound 1; then compounds 2 and 4 (each within the scatter of the next).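

On a sulfur, 3,4-dichlorophenyl in place of 4-fluorophenyl gives a 1.0-fold higher number from compound 2 to compound 4 (0.02 log units; within the scatter) in this assay. The step lies within the scatter, so this swap of halogens on the phenyl ring, with one more heavy atom entering than leaving, does not separate the two compounds. No measurement at hand offers a reason for this result.

What the compounds leave open is whether a carboxylic acid or an amine on that phenyl ring, or a longer chain on the sulfur, would give a number that stands apart from those of compound 2 and compound 4.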